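The source may report more compounds than this note shows. Statements on the series, on what has been measured and on what is new or still open speak of the compounds shown alone.

Compound 2 `COc1ccccc1-c1cn(C[C@H](O)[C@H]2OC(=O)C(OCc3ccccc3)=C2OCc2ccccc2)nn1` is the starting point of this comparison. In a functional assay on HCT-116 cells (Homo sapiens) for antiproliferative activity, read by MTT assay, with a stated time of 72 h (a higher number here means a weaker inhibitor, a lower number a stronger inhibitor), compound 2 gives > 100000 nM, which is a limit of the assay rather than a number. Among the measured compounds, only compound 1 `CCCCc1cn(C[C@H](O)[C@H]2OC(=O)C(OCc3ccccc3)=C2OCc2ccccc2)nn1` gives a number, 10400 nM. Among the compounds with values here, the one measured step that touches compound 2 is an at least 9.6-fold higher number from compound 1 to compound 2 (0.98 log units; beyond the scatter). Compound 3 `COc1ccccc1-c1cn(C/C=C2\OC(=O)C(OCc3ccccc3)=C2OCc2ccccc2)nn1` gives > 100000 nM, again a limit. So the limit of > 100000 nM in this assay, at which 2 of the 3 values shown sit, describes where most of the known values sit.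

Compound 4 `O=C1O[C@H]([C@@H](O)Cn2cc(CNS(=O)(=O)c3ccc(Cl)cc3)nn2)C(OCc2ccccc2)=C1OCc1ccccc1` differs from compound 2 in one place: (((4-chlorophenyl)sulfonyl)amino)methyl in place of 2-methoxyphenyl on an aromatic carbon. No measured step covers such a change, and because the starting value of compound 2 is itself a limit, the size of the step cannot be read from the numbers shown. Compound 4 is therefore estimated at 70000 nM, with a range from 15000 nM to 300000 nM. That estimate corresponds to an expected step of an at least 1.4-fold lower number from compound 2 to compound 4 (0.15 log units; that floor lies within the scatter).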

Compound 4, half-maximal inhibitory concentration: 8380 nM
Estimate against measurement, compound 4: 8.4-fold (0.92 log units) above; measured number below the stated range.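

Carrying a six-membered aromatic ring in the group on this triazole carbon does not by itself put a compound out of reach of this assay, since replacing 2-methoxyphenyl with (((4-chlorophenyl)sulfonyl)amino)methyl gives an at least 11-fold lower number from compound 2 to compound 4 (1.07 log units; beyond the scatter). That size is only a floor, because compound 2 sits at a limit: the limit of > 100000 nM in this assay, at which 2 of the 4 values shown sit. The butyl group and the larger (((4-chlorophenyl)sulfonyl)amino)methyl group cannot be told apart in this assay, with a 1.2-fold lower number from compound 1 to compound 4 (0.09 log units; within the scatter).

The compounds shown leave open which part of the new group matters, for instance whether a plain aminomethyl or an unsubstituted phenylsulfonyl version would behave the same, and how a longer alkyl chain such as octyl would compare with butyl. They also leave open whether this group would give a measurable value on the core of compound 3.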